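A few compounds are considered here, and "the series" means these few. Any claim that something is new, unique, unknown or untested is made for them only; others in the source may bear on it.

Notes on the series. Compound 1 `Cc1nc(C(F)(F)F)ccc1C(=O)Nc1ccc(Cl)c(-c2nc3ccccc3[nH]2)c1` gives 12 nM in an assay on C3H 10T1/2 cells for inhibition of Sonic hedgehog protein (Mus musculus), read by a luciferase reporter; on this read-out lower numbers stand for stronger inhibition and higher numbers for weaker inhibition. Compound 2 `Cc1nc(C(F)(F)F)ccc1C(=O)Nc1ccc(Cl)c(-c2nc3ccccc3s2)c1` gives 70 nM in this assay. Compound 3 `Cc1nc(C(F)(F)F)ccc1C(=O)Nc1ccc(Cl)c(-c2ccn(C)n2)c1` gives 550 nM in this assay, the highest of the three numbers. Compound 4 `Cc1nc(C(F)(F)F)ccc1C(=O)Nc1ccc(Cl)c(-c2cnc3ccccc3n2)c1` is not yet measured; it differs from compound 3 by quinoxalin-2-yl in place of 1-methyl-1H-pyrazol-3-yl on an aromatic carbon. For the measured compounds named here, two measured steps bear on this exchange, both running the opposite way: a 46-fold higher number from compound 1 to compound 3 (1.66 log units; beyond the scatter) and a 7.9-fold higher number from compound 2 to compound 3 (0.90 log units; beyond the scatter). The entering group, like those of compound 1 and compound 2, has two rings rather than one, so a step in this assay back toward lower numbers is expected, of a size between those two. Compound 4 is accordingly estimated at 80 nM in this assay, with a range of 25 nM to 300 nM. The expected step is a 6.9-fold lower number from compound 3 to compound 4 (0.84 log units; beyond the scatter).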

Compound 4, half-maximal inhibitory concentration: 52 nM
The estimate for compound 4 lay 1.5-fold (0.19 log units) above the measured number; the range from low to high includes it.
By their numbers in this assay, from the lowest: compound 1; then compounds 4 and 2 (each within the scatter of the next); then compound 3.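

In this assay this position accepts a pair of six-membered rings as well as a five-membered ring paired with a six-membered one: quinoxalin-2-yl gives an 11-fold lower number from compound 3 to compound 4 (1.02 log units; beyond the scatter), and its exchange for 1,3-benzothiazol-2-yl gives a 1.3-fold lower number from compound 2 to compound 4 (0.13 log units; within the scatter). 1H-benzimidazol-2-yl remains apart from quinoxalin-2-yl, with a 4.3-fold higher number from compound 1 to compound 4 (0.64 log units; beyond the scatter). Nothing at hand explains these steps.

Whether two rings are needed stays open, as 1-methyl-1H-pyrazol-3-yl is the only single-ring group shown. A phenyl or pyridinyl group here would test this, and an aminomethyl group would show how a non-ring amine behaves.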